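This account rests on a few compounds, and the source may have more. Where it says the series, first, only, none or still open, it means among the compounds named here.

Three compounds here share one core and differ only in how the outer ring is substituted. Compound 1 `C=C(Br)C(=O)Nc1cccc(/C=C/C(=O)Nc2ccccc2)c1` carries that ring bare; in a functional assay on CCRF-CEM cells (Homo sapiens) for inhibition, read by MTT assay, with a stated time of 72 h (a lower number here means a stronger inhibitor, a higher number a weaker inhibitor), compound 1 gives 190 nM. Compound 2 `C=C(Br)C(=O)Nc1cccc(/C=C/C(=O)Nc2ccc(OC)cc2)c1` differs by methoxy in place of hydrogen on an aromatic carbon, and in this assay compound 2 gives 26 nM, a step that is a 7.3-fold lower number from compound 1 to compound 2 (0.86 log units; beyond the scatter). Compound 3 `C=C(Br)C(=O)Nc1cccc(/C=C/C(=O)Nc2cc(OC)cc(OC)c2)c1` carries two methoxy groups; the difference between its core and that of compound 1 is not broken down here. In this assay compound 3 gives 11 nM, lower than compound 2 and compound 1 and the lowest of the three.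

Compound 4 `C=C(Br)C(=O)Nc1cccc(/C=C/C(=O)Nc2cc(OC)c(OC)c(OC)c2)c1` is still to be measured. It differs from compound 3 by methoxy in place of hydrogen on an aromatic carbon, the same kind of change as from compound 1 to compound 2, though here the entering group sits ortho to two methoxy groups and para to a large group, whereas in compound 2 it sits para to a large group only. The step to compound 4 is expected to be small, a 1.4-fold lower number from compound 3 to compound 4 (0.14 log units; within the scatter), since the gain seen in a 7.3-fold lower number from compound 1 to compound 2 (0.86 log units; beyond the scatter) shrank when compound 3 went beyond compound 2. Compound 4 is therefore expected to give about 8 nM in this assay, plausibly between 3 nM and 25 nM.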

Compound 4, half-maximal inhibitory concentration: 59 nM
The estimate for compound 4 lay 7.4-fold (0.87 log units) below the measured number, outside the stated range (above it).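

Swapping a hydrogen on the outer ring for a methoxy group does not carry a fixed effect from one core to another in this series: in this assay, the new step is a 5.4-fold higher number from compound 3 to compound 4 (0.73 log units; beyond the scatter), opposite in direction to the gain seen when the same change was made on the core of compound 1. Set side by side, the two steps clearly disagree: the same change on two cores in this assay, a 7.3-fold lower number (0.86 log units; beyond the scatter) from compound 1 to compound 2 and a 5.4-fold higher number (0.73 log units; beyond the scatter) from compound 3 to compound 4, 39-fold (1.59 log units) apart, beyond the scatter of two such steps

In compound 4 the entering group sits ortho to two methoxy groups, unlike in compound 2, but two steps cannot show whether that difference in place is what reverses the direction.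

Going by these compounds, it remains open whether a hydroxyl group, an ethoxy group or a fluorine atom in that same place would keep the number that compound 3 gives, 11 nM, or raise it as methoxy does. Also open, on these data alone, is how an amine or a carboxylic acid on the outer ring would compare with the methoxy groups.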